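The source may hold more compounds than are shown below. What is called first, only, known or untested is meant among the compounds shown, and "the series" means these compounds.

Measured compounds:
compound 1 `CC1(C)CCN1S(=O)(=O)c1cncc(-c2ccn3nc(N)nc3c2)c1` gives 50100000 nM in an assay on isolated protein for inhibition of phosphatidylinositol 4,5-bisphosphate 3-kinase catalytic subunit beta isoform (Homo sapiens); a higher number here means a weaker inhibitor, a lower number a stronger inhibitor
compound 2 `CS(=O)(=O)c1cncc(-c2ccn3nc(N)nc3c2)c1` gives 39800000 nM in this assay

Compound 1 stands with the highest number of the two; its nearest neighbour is compound 2, and the step of a 1.3-fold lower number from compound 1 to compound 2 (0.10 log units; within the scatter) is within the scatter, so the two cannot be ordered. Compound 3 `Nc1nc2cc(-c3cncc(S(=O)(=O)NCc4ccccc4)c3)ccn2n1` is not yet measured. It differs from compound 1 by benzylamino in place of 2,2-dimethylazetidin-1-yl on a sulfonyl sulfur. Among the measured compounds shown here, the only measured step that bears on this change is the one at the same sulfonyl sulfur, from compound 1 to compound 2, where replacing the 2,2-dimethylazetidin-1-yl with a methyl gave a 1.3-fold lower number from compound 1 to compound 2 (0.10 log units; within the scatter). With so small a change seen at this position, no step beyond the scatter is expected in this assay. Compound 3 is therefore estimated at 45000000 nM, with a range from 15000000 nM to 150000000 nM, which corresponds to an expected step of a 1.1-fold lower number from compound 1 to compound 3 (0.05 log units; within the scatter).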

Compound 3, half-maximal inhibitory concentration: 25100000 nM
Beside the measured number, compound 3's estimate is 1.8-fold (0.25 log units) above it; the range from low to high includes it.
By their numbers in this assay, from the lowest: compounds 3, 2 and 1 (each within the scatter of the next).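

On the sulfonyl sulfur, benzylamino gives a 2.0-fold lower number from compound 1 to compound 3 (0.30 log units; within the scatter) and a 1.6-fold lower number from compound 2 to compound 3 (0.20 log units; within the scatter) in this assay. The earlier pair held no aromatic ring and no hydrogen-bond donor in the group at this place, and bringing in both still gives no step beyond the scatter, so methyl, 2,2-dimethylazetidin-1-yl and benzylamino cannot be ordered here. No measurement shown offers an explanation for this result.

The three compounds leave open whether any group on the sulfonyl sulfur can move the number beyond the scatter, for example a carboxylic acid at the end of a longer chain or a piperazine. They also leave open whether a change elsewhere on the shared core would do so.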